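Removing the Methyl from a Phenol Oxygen

The compounds below may be only part of what the source reports. "The series", "measured", "known", "first", "only" and "open" are said of these compounds alone.

Measured so far:
compound 1 `O=C(Nc1cccc(-n2cc(-c3ccncc3)c(-c3ccc(Cl)c(O)c3)n2)c1)Nc1cccc(C(F)(F)F)c1`: > 32500 nM 
compound 2 `O=C(Nc1cccc(-n2cc(-c3ccncc3)c(-c3ccc(Cl)c(O)c3)n2)c1)Nc1ccc(Cl)c(Cl)c1`: 17900 nM 
compound 3 `COc1cc(-c2nn(-c3cccc(NC(=O)Nc4ccc(Cl)c(C(F)(F)F)c4)c3)cc2-c2ccncc2)ccc1Cl`: > 32500 nM 

In a functional assay on T47D cells (Homo sapiens) for inhibition, read by sulforhodamine B assay, with a stated time of 48 h (on this read-out higher numbers stand for weaker inhibition of growth and lower numbers for stronger inhibition of growth), compound 3 gives > 32500 nM, which is a limit of the assay rather than a number. Compound 1 gives > 32500 nM, also a limit. Compound 2 gives 17900 nM, the only true number shown. Going by the values given here, the step of an at least 1.8-fold lower number from compound 1 to compound 2 (0.25 log units; that floor lies within the scatter) is the one measured step. Two of the three values sit at the limit of > 32500 nM in this assay, at which 2 of the 3 values shown sit, so compound 3 stands at the weak edge of what this assay can report.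

Compound 4 `O=C(Nc1cccc(-n2cc(-c3ccncc3)c(-c3ccc(Cl)c(O)c3)n2)c1)Nc1ccc(Cl)c(C(F)(F)F)c1` differs from compound 3 by hydrogen in place of methyl on an oxygen on an aromatic ring, that is, methoxy to hydroxy on the 4-chloro-3-methoxyphenyl group. Among the compounds with values here, no measured step touches that oxygen, so the measured step from compound 1 to compound 2 bears only indirectly. With two of three values at the limit, compound 4 is expected to give 28000 nM, between 11000 nM and 70000 nM. The expected step reads an at least 1.1-fold lower number from compound 3 to compound 4 (0.06 log units; that floor lies within the scatter), no change beyond the scatter.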

Compound 4, concentration for total growth inhibition: > 32500 nM
Compound 4: only a limit was reported; the forecaster's own chance of this, stated with the estimate: 55%; at least 1.1-fold (0.06 log units) between middle value and limit.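

With hydroxy in place of methoxy on the 4-chloro-3-methoxyphenyl group, compound 4 still gives only a limit in this assay, so this change does not yield a true number here. The steps from compound 3 to compound 4 and from compound 1 to compound 4 cannot be read, because both ends of each step are the same limit: the limit of > 32500 nM in this assay, at which 3 of the 4 values shown sit.

The one readable step is an at least 1.8-fold higher number from compound 2 to compound 4 (0.25 log units; that floor lies within the scatter), with trifluoromethyl in place of chloro on an aromatic carbon, so compound 2 remains the only compound with a true number, and even this step is not shown to exceed the scatter.

On these data alone, whether methoxy and hydroxy differ at all on this oxygen therefore stays open. So does whether an ethoxy group or an amine at that place on the ring would give a true number in this assay.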